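Replacing 2-methoxybenzyl with 2-bromobenzyl in compound 3

This account rests on a few compounds, and the source may have more. Where it says the series, first, only, none or still open, it means among the compounds named here.

In a functional assay on HepG2 cells (Homo sapiens) for antiproliferative activity, read by MTT assay, with a stated time of 48 h (a lower number here means a stronger inhibitor, a higher number a weaker inhibitor), compound 1 (`Oc1ccccc1CNc1ccc2ncnc(Nc3cccc(Br)c3)c2c1`) gives 1260 nM, compound 2 (`COc1ccccc1CNc1ccc2ncnc(Nc3cccc(Br)c3)c2c1`) gives 8820 nM and compound 3 (`COc1ccccc1CNc1ccc2ncnc(Nc3cccc(Cl)c3)c2c1`) gives 9850 nM. Compound 3 therefore stands level with compound 2, and both carry clearly higher numbers than compound 1. The next structure is compound 4 (`Clc1cccc(Nc2ncnc3ccc(NCc4ccccc4Br)cc23)c1`), which differs from compound 3 as follows: bromo in place of methoxy on an aromatic carbon. This places bromo in place of methoxy on an aromatic carbon, ortho to a large group, turning 2-methoxyphenyl into 2-bromophenyl. For the measured compounds named here, no measured step makes this exchange. The closest one alters the same methoxy group, with methyl in place of hydrogen on an oxygen on an aromatic ring, and it gave a 7.0-fold higher number from compound 1 to compound 2 (0.85 log units; beyond the scatter). The chloro in place of bromo change lies elsewhere and gave a 1.1-fold higher number from compound 2 to compound 3 (0.05 log units; within the scatter). With no direction established for the new exchange, a step beyond the scatter is not expected, and the expected step is a 1.4-fold lower number from compound 3 to compound 4 (0.15 log units; within the scatter). Compound 4 is estimated at 7000 nM, with an expected range from 2500 nM to 20000 nM.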

Compound 4, half-maximal inhibitory concentration: 4170 nM
Compound 4: the middle estimate sits 1.7-fold (0.22 log units) above what was measured; the measured number falls inside the stated range.
By their numbers in this assay, from the lowest: compound 1; then compound 4; then compounds 2 and 3 (each within the scatter of the next).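

In this assay, bromo in place of methoxy gives a 2.4-fold lower number from compound 3 to compound 4 (0.37 log units; beyond the scatter) and so a modest step beyond the scatter. The earlier compounds had shown only a change on the oxygen of this group, where methyl in place of hydrogen gave a 7.0-fold higher number from compound 1 to compound 2 (0.85 log units; beyond the scatter) in the opposite direction. Compound 4 adds that the number at this position does not depend on keeping that oxygen, since a single bromo atom on the aromatic carbon, with no hydrogen-bond acceptor, gives a lower number than the methoxy group of compound 3.

Going by these compounds, whether an amine, a carboxylic acid or a longer chain at this position would lower the number further, and whether the same exchange carries over to compound 2, remains open. The data shown offer nothing that accounts for this step.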